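A few compounds are considered here, and "the series" means these few. Any claim that something is new, unique, unknown or untested is made for them only; others in the source may bear on it.

Measured in an assay on microsomes for inhibition of acyl-CoA:cholesterol acyltransferase (Oryctolagus cuniculus); on this read-out lower numbers stand for stronger inhibition and higher numbers for weaker inhibition:
compound 1 `Cc1ccc(C2(CNC(=O)Nc3c(C(C)C)cccc3C(C)C)CCCC2)cc1`: 25 nM
compound 2 `CC(C)c1cccc(C(C)C)c1NC(=O)NCC1(c2ccc(C(C)(C)C)cc2)CCCC1`: 63 nM
compound 3 `COC(=O)c1cccc(C2(CNC(=O)Nc3c(C(C)C)cccc3C(C)C)CCCC2)c1`: 34 nM

Compound 1 gives the lowest of the three numbers in this assay; compound 3 sits within the scatter of it, compound 2 beyond it. The step to compound 4 `COC(=O)c1ccc(C2(CNC(=O)Nc3c(C(C)C)cccc3C(C)C)CCCC2)cc1` is methoxycarbonyl in place of methyl on an aromatic carbon. For the measured compounds named here, two measured steps bear on it: a 1.4-fold higher number from compound 1 to compound 3 (0.13 log units; within the scatter), and a 2.5-fold higher number from compound 1 to compound 2 (0.40 log units; beyond the scatter). Putting methoxycarbonyl onto the phenyl ring as 3-(methoxycarbonyl)phenyl left the number within the scatter, while enlarging the methyl to tert-butyl raised it modestly. For compound 4 a change no larger than the scatter, if anything a small rise, is therefore expected: a 1.4-fold higher number from compound 1 to compound 4 (0.15 log units; within the scatter). Compound 4 is estimated at 35 nM, in the range 15 nM to 80 nM.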

Compound 4, half-maximal inhibitory concentration: 360 nM
Compound 4: the middle estimate sits 10-fold (1.01 log units) below what was measured; measured number outside the range, above it.
By their numbers in this assay, from the lowest: compounds 1, 3 and 2 (each within the scatter of the next, the first and the last beyond it); then compound 4.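

Where the methoxycarbonyl sits on the phenyl ring matters: moving it gives an 11-fold higher number from compound 3 to compound 4 (1.02 log units; beyond the scatter), so the tolerance seen for 3-(methoxycarbonyl)phenyl does not carry over to 4-(methoxycarbonyl)phenyl. At this aromatic carbon, methoxycarbonyl is also worse than either alkyl group, with a 14-fold higher number from compound 1 to compound 4 (1.16 log units; beyond the scatter) and a 5.7-fold higher number from compound 2 to compound 4 (0.76 log units; beyond the scatter). Nothing available explains the rise. As far as these compounds go, whether it is specific to methoxycarbonyl remains open. A carboxylic acid, a primary amide or a nitrile at the same place would show how far it extends.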